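The compounds below may be only part of what the source reports. "The series", "measured", "known", "first", "only" and "open" are said of these compounds alone.

Measured compounds:
Compound 1, `O=C(Nc1ccc(Cl)c(-c2nnc3c(Cl)cccn23)c1)c1ccccc1` — 58200 nM
Compound 2, `Cc1nc(C(=O)Nc2ccc(Cl)c(-c3nnc4c(Cl)cccn34)c2)cs1` — > 100000 nM
Compound 3, `CS(=O)(=O)c1ccc(C(=O)Nc2ccc(Cl)c(-c3nnc4c(Cl)cccn34)c2)cc1` — > 100000 nM

For the measured compounds named here, in a functional assay on MDA-MB-231 cells (Homo sapiens) for antiproliferative activity, read by MTT assay, with stated times of 72 h and 4 h (a higher number here means a weaker inhibitor, a lower number a stronger inhibitor), compound 1 gives the only number of the three; its reading is 58200 nM. Compound 2 gives only a limit, > 100000 nM. Compound 3 likewise gives only a limit, > 100000 nM. Both limits sit at the limit of > 100000 nM in this assay, at which 2 of the 3 values shown sit. The steps of an at least 1.7-fold higher number from compound 1 to compound 2 (0.23 log units; that floor lies within the scatter) and an at least 1.7-fold higher number from compound 1 to compound 3 (0.23 log units; that floor lies within the scatter) are thus floors only, and a step that the two limits leave unreadable from compound 2 to compound 3 cannot be read.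

Compound 4, `O=C(Nc1ccc(Cl)c(-c2nnc3c(Cl)cccn23)c1)c1ccc(F)cc1Cl`, differs from compound 1 by 2-chloro-4-fluorophenyl in place of phenyl on a carbonyl carbon. Going by the values given here, no measured step changes the benzamide ring by halogens alone, so none bears directly on this change. The two measured steps that alter the carbonyl-bound ring both reached the limit, which gives no direction. Compound 4 is therefore expected to stay near compound 1, a 1.2-fold lower number from compound 1 to compound 4 (0.07 log units; within the scatter), with an estimated value of 50000 nM between 15000 nM and 150000 nM.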

Compound 4, half-maximal inhibitory concentration: 75000 nM
Estimate against measurement, compound 4: 1.5-fold (0.18 log units) below; low and high end bracket the measured number.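

In this assay, 2-chloro-4-fluorophenyl in place of phenyl on the carbonyl carbon gives a 1.3-fold higher number from compound 1 to compound 4 (0.11 log units; within the scatter) and so, unlike the two earlier replacements there, still returns a number rather than a limit. The steps of an at least 1.3-fold lower number from compound 3 to compound 4 (0.12 log units; that floor lies within the scatter) and an at least 1.3-fold lower number from compound 2 to compound 4 (0.12 log units; that floor lies within the scatter) are floors only and set no order among these compounds. Compound 2 and compound 3 each give only a limit: the limit of > 100000 nM in this assay, at which 2 of the 4 values shown sit.

On these data alone, what an amine or a carboxylic acid on this ring would do remains open, as does whether chlorine or fluorine alone would behave as the pair does.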